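Carbonyl substituent change followed in the cell growth assay

The compounds below may be only part of what the source reports. "The series", "measured", "known", "first", "only" and "open" are said of these compounds alone.

Measured compounds:
Compound 1 `CNC(=O)c1cc(Oc2ccc3nc(NC(=O)Nc4ccc(Cl)cc4)sc3c2)ccn1` gives 85.2% in a functional assay on HCT-116 cells (Homo sapiens) for inhibition, read by MTT assay, with a stated time of 2 days, tested at 100 uM; a higher number here means more inhibition of growth at the concentration tested, a lower number less inhibition of growth.
Compound 2 `CNC(=O)c1cc(Oc2ccc3nc(NC(=O)c4cccc(F)n4)sc3c2)ccn1` gives 55.5% in this assay.

Compound 2 holds the lower of the two numbers; the step of a number 29.7 percentage points lower from compound 1 to compound 2 (beyond the scatter) lies beyond the scatter. Compound 3 `CNC(=O)c1cc(Oc2ccc3nc(NC(=O)Nc4ccc(Cl)cc4Cl)sc3c2)ccn1` is not yet measured. Its change from compound 2 is (2,4-dichlorophenyl)amino in place of 6-fluoropyridin-2-yl on a carbonyl carbon. Within the data shown here, the only step that bears on this is a number 29.7 percentage points lower from compound 1 to compound 2 (beyond the scatter), which removed an arylamino from the carbonyl carbon; compound 3 restores an arylamino, so an upward step is expected, roughly reversing that one, as a number 24.5 percentage points higher from compound 2 to compound 3 (beyond the scatter). Compound 3 is therefore estimated at 80%, with a range of 60% to 95%.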

Compound 3, percent growth inhibition at one concentration: 93.6%
Estimate against measurement, compound 3: 13.6 percentage points below; the measured number falls inside the stated range.
By their numbers in this assay, from the lowest: compound 2; then compounds 1 and 3 (each within the scatter of the next).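

On the carbonyl carbon, (2,4-dichlorophenyl)amino in place of 6-fluoropyridin-2-yl gives a number 38.1 percentage points higher from compound 2 to compound 3 (beyond the scatter) in this assay; both arylamino compounds now stand clear of the 6-fluoropyridin-2-yl compound. The added chloro on the aromatic carbon gives a number 8.4 percentage points higher from compound 1 to compound 3 (within the scatter), so the two arylamino compounds cannot be told apart here. Nothing measured bears on the cause of these differences.

Still open, as far as these compounds go, is whether the amino nitrogen or the ring identity drives the difference; a pyridin-2-ylamino on the same carbonyl carbon would separate the two. Also open, from the compounds shown here alone, is how a benzylamino or morpholine group would read at this position.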